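A few compounds are considered here, and "the series" means these few. Any claim that something is new, unique, unknown or untested is made for them only; others in the source may bear on it.

Measured so far:
- compound 1 `COc1ccc(/C=C/[C@@](C)(/C=C/c2ccc(O)cc2)CCC=C(C)C)cc1`: 52%
- compound 2 `CC(C)=CCC[C@](C)(/C=C/c1ccc(O)cc1)/C=C/c1ccc(F)cc1`: 60%

Within the data shown here, in a functional assay on THP-1 cells (Homo sapiens) for inhibition, with a stated time of 48 h, tested at 50 uM (a lower number here means less inhibition of growth, a higher number more inhibition of growth at the concentration tested), compound 1 stands within the scatter of compound 2, the only other compound measured, so the two cannot be ranked. Among the measured compounds shown here, the single measured step is a number 8 percentage points higher from compound 1 to compound 2 (within the scatter), which comes from fluoro in place of methoxy on an aromatic carbon.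

Compound 3 `COc1ccc(/C=C/[C@@](C)(/C=C/c2ccc(O)cc2)CCC=C(C)C)cc1CO` keeps the core of compound 1 and its methoxy group, and differs as follows: hydroxymethyl in place of hydrogen on an aromatic carbon. The new hydroxymethyl sits ortho to a methoxy group and meta to a large group. For the measured compounds named here, no measured compound carries hydroxymethyl, so the data hold no direct precedent for this change. Going by the values given here, the one step available is a change on the same ring, and it bears only indirectly. Its size gives no ground for expecting a large shift in this assay, and it gives no direction for this change. No step beyond the scatter is therefore expected, and the estimate is a number 4 percentage points lower from compound 1 to compound 3 (within the scatter). For compound 3 the estimated value is 48%, with an expected range of 32% to 64%.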

Compound 3, percent growth inhibition at one concentration: 58%
The estimate for compound 3 lay 10 percentage points below the measured number; measured number inside the range.
By their numbers in this assay, from the lowest: compounds 1, 3 and 2 (each within the scatter of the next).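

Working notes on the series: in this assay, hydroxymethyl in place of hydrogen on an aromatic carbon, ortho to a methoxy group and meta to a large group, gives a number 6 percentage points higher from compound 1 to compound 3 (within the scatter). The step from compound 1 to compound 2 covered only replacement of the methoxy group, whereas this result covers a ring position that carries hydrogen in compound 1, and it shows that adding hydroxymethyl there, with the methoxy group kept, produces no step beyond the scatter in this single-concentration read-out. No measurement is available that accounts for the size of this step.

On these data alone, whether an aminomethyl group, a carboxylic acid or a longer chain such as hydroxyethyl at this same position would also stay within the scatter remains open. Also open, as far as these compounds go, is whether hydroxymethyl at this position would give a comparable step on the fluoro-bearing ring of compound 2, and whether any difference between compound 1 and compound 3 would appear in a full concentration series.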